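The source may hold more compounds than are shown below. What is called first, only, known or untested is meant among the compounds shown, and "the series" means these compounds.

Working notes on the series. Among the measured compounds shown here, compound 1 `CCC/C=C/C(=O)N(Cc1ccc(OC)c(O)c1)c1cc(OC)c(OC)c(OC)c1` gives 57 nM in a functional assay on KYSE-450 cells (Homo sapiens) for inhibition, read by MTT assay, with a stated time of 48 h (on this read-out higher numbers stand for weaker inhibition and lower numbers for stronger inhibition), and stands lowest of the three numbers measured so far. Compound 3 `C/C=C/C(=O)N(Cc1ccc(OC)c(N)c1)c1cc(OC)c(OC)c(OC)c1` gives 310 nM in this assay, and compound 2 `C#CC(=O)N(Cc1ccc(OC)c(O)c1)c1cc(OC)c(OC)c(OC)c1` gives 570 nM, so both other members sit well above compound 1. For the measured compounds named here, the only single-point step measured is a 10-fold higher number from compound 1 to compound 2 (1.00 log units; beyond the scatter), where the pent-1-en-1-yl chain is replaced by ethynyl on the carbonyl carbon. Compound 4 `C/C=C/C(=O)N(Cc1ccc(OC)c(O)c1)c1cc(OC)c(OC)c(OC)c1` differs from compound 1 by hydrogen in place of ethyl on a saturated chain carbon bound to a double-bonded chain carbon. This is a shortening of the same chain, but a smaller one than the ethynyl step, so a rise in the number that is beyond the scatter yet short of that step is expected. The number for compound 4 is expected to move by a 2.8-fold higher number from compound 1 to compound 4 (0.45 log units; beyond the scatter). Compound 4 is estimated at 160 nM, with a range from 65 nM to 400 nM.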

Compound 4, half-maximal inhibitory concentration: 67 nM
Compound 4: middle estimate off by 2.4-fold (0.38 log units), on the high side; low and high end bracket the measured number.
By their numbers in this assay, from the lowest: compounds 1 and 4 (each within the scatter of the next); then compounds 3 and 2 (each within the scatter of the next).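

The alkenyl chain on the carbonyl carbon tolerates shortening from pent-1-en-1-yl to prop-1-en-1-yl, with a 1.2-fold higher number from compound 1 to compound 4 (0.07 log units; within the scatter), whereas prop-1-en-1-yl in place of ethynyl gives an 8.5-fold lower number from compound 2 to compound 4 (0.93 log units; beyond the scatter), so shortening the alkenyl chain alone does not reproduce the ethynyl step. Among the compounds shown here, compound 4 also gives the first single-point reading on the aromatic carbon, where hydroxy in place of amino gives a 4.6-fold lower number from compound 3 to compound 4 (0.67 log units; beyond the scatter). No measurement here accounts for either finding. On these data alone, whether a longer chain than pent-1-en-1-yl or a saturated propyl chain keeps the number remains open. So does the effect of fluorine on that aromatic carbon.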